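This account rests on a few compounds, and the source may have more. Where it says the series, first, only, none or still open, it means among the compounds named here.

Measured compounds:

Compound 1, `O=C(O)COc1ccc(NC(=O)C(=O)Nc2ccccc2)cc1F`: 9.78%
Compound 2, `Cc1ccccc1OCC(=O)Nc1ccc(OCC(=O)O)c(F)c1`: 20.8%

Both were tested in a functional assay on CHO cells for agonist activity at Free fatty acid receptor 1 (Homo sapiens), read by FLIPR, tested at 100 nM; on this read-out higher numbers stand for a stronger effect at the one concentration tested and lower numbers for a weaker effect. On these two numbers compound 2 stands highest; its nearest neighbour is compound 1, whose reading lies lower by a gap beyond the usual scatter. Among the compounds with values here, no pair of measured compounds differs in just one place, so no single measured step exists to lean on.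

Compound 3, `Cc1ccc(OCC(=O)Nc2ccc(OCC(=O)O)c(F)c2)cc1`, is not yet measured. It differs from compound 2 only in the way the same atoms are joined: 4-methylphenyl in place of 2-methylphenyl on an oxygen on a saturated carbon. Because compound 2 gives 20.8% and compound 3 keeps every one of its atoms with only the methyl moved around the ring, the step from compound 2 to compound 3 is expected to be small, with no clear direction, and most likely within the scatter: a number 1.2 percentage points higher from compound 2 to compound 3 (within the scatter). For compound 3 in this assay the estimate is therefore 22%, with a range from 8% to 40%.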

Compound 3, a percentage reported as activity, at one concentration (the size of the read-out at that concentration, not a potency): 31.2%
Estimate against measurement, compound 3: 9.2 percentage points below, and the stated range covers the measured number.
By their numbers in this assay, from the lowest: compound 1; then compound 2; then compound 3.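

Swapping 2-methylphenyl for 4-methylphenyl, on an oxygen on a saturated carbon, gives a number 10.4 percentage points higher from compound 2 to compound 3 (beyond the scatter) in this assay. Within the data shown here, this is the first single change that can be read, and it shows that the reading at this position depends on where the methyl sits on the ring, even though the two compounds have the same atoms. Nothing available explains this difference.

The compounds shown leave open whether the methyl itself matters, or whether an ethyl, a methoxy or a chlorine in its place would give a higher or lower reading. Since each reading comes from a single concentration, they also leave open how compound 2 and compound 3 compare in potency.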